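Three inert sulfonamides and a fourth awaiting its reading

This account rests on a few compounds, and the source may have more. Where it says the series, first, only, none or still open, it means among the compounds named here.

Compound 1, `CC1CCN(C2CCN(S(=O)(=O)c3cccc(-c4ccccc4C(F)(F)F)c3)CC2)CC1`, gives > 5000 nM in an ADME assay on HCT-116 cells (Homo sapiens) for cytotoxicity, read by CellTiter-Glo, with a stated time of 72 h (a lower number here means a stronger inhibitor, a higher number a weaker inhibitor), which is a limit of that assay rather than a number.
Compound 2, `CC1CCN(C2CCN(S(=O)(=O)c3cccc(Br)c3)CC2)CC1`, gives > 5000 nM in this assay, again a limit.
Compound 3, `CC1CCN(C2CCN(S(=O)(=O)c3cccc(-c4ccc(Cl)cc4)c3)CC2)CC1`, gives > 5000 nM in this assay, also a limit.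

Compound 2 therefore stands where every measured compound stands: at the limit of > 5000 nM in this assay, at which 3 of the 3 values shown sit. All three readings are limits. The step that the two limits leave unreadable from compound 1 to compound 2, the step that the two limits leave unreadable from compound 1 to compound 3 and the step that the two limits leave unreadable from compound 2 to compound 3 cannot be given a size; the group on the aromatic carbon has been changed from bromo to a trifluoromethylphenyl and to a chlorophenyl without any compound leaving the limit.

Compound 4, `CC1CCN(C2CCN(S(=O)(=O)c3ccc(Br)c(Cl)c3)CC2)CC1`, is the next variation on the same theme. It differs from compound 2 in one place: 4-bromo-3-chlorophenyl in place of 3-bromophenyl on a sulfonyl sulfur. For the measured compounds named here, the only measured steps that bear on this change are the three unreadable ones around compound 2, none of which shows movement away from the limit.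

Compound 4 is accordingly expected to sit at the limit once more, with a step that the limit leaves unreadable from compound 2 to compound 4 that is expected to stay within the scatter. The estimate for compound 4 in this assay is 9000 nM, with a range from 3500 nM to 30000 nM.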

Compound 4, half-maximal inhibitory concentration: > 5000 nM
Compound 4 was reported as a limit; the forecaster's own chance of this, stated with the estimate: 85%; the middle value is on the limit's open side.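

In this assay compound 4 gives > 5000 nM, which is a limit of the assay, so no size can be read for the change from compound 2 to compound 4. The compounds shown leave open how far each lies past the limit, and whether any group on the sulfonyl sulfur would yield a measurable value.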